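The source may hold more compounds than are shown below. What is called first, only, known or untested is meant among the compounds shown, and "the series" means these compounds.

Three compounds were examined in an ADME assay on NHDF cells (Homo sapiens) for cytotoxicity, read by MTT assay, with a stated time of 72 h; a lower number here means a stronger inhibitor, a higher number a weaker inhibitor. Compound 1 `COc1cccc(/C=C2\CCC/C(=C\c3ccc(Cl)cc3)C2=O)c1OC` gives 18600 nM in this assay, compound 2 `COc1ccc(/C=C2\CCC/C(=C\c3cccc(OC)c3OC)C2=O)cc1` gives 43500 nM, and compound 3 `COc1ccc(/C=C2\CCC/C(=C\c3ccc(O)c(Cl)c3)C2=O)cc1OC` gives 21900 nM. Between compound 1 and compound 2 the change methoxy in place of chloro on an aromatic carbon produced a 2.3-fold higher number from compound 1 to compound 2 (0.37 log units; beyond the scatter). Compound 3 sits within the scatter of both compound 1 and compound 2, and the difference between the core of compound 3 and the core of compound 1 is not broken down here. Compound 4 `COc1cc(/C=C2\CCC/C(=C\c3ccc(OC)c(OC)c3)C2=O)ccc1O` carries the same kind of change, (methoxy in place of chloro on an aromatic carbon); in compound 4 the entering group stands ortho to a hydroxy group and meta to a large group, whereas in compound 2 it stands para to a large group. Because the earlier change gave a 2.3-fold higher number from compound 1 to compound 2 (0.37 log units; beyond the scatter), a modest step is expected again. For compound 4 this means an expected step of a 1.9-fold higher number from compound 3 to compound 4 (0.28 log units; within the scatter). Compound 4 is estimated at 42000 nM, with a range from 20000 nM to 85000 nM.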

Compound 4, half-maximal inhibitory concentration: 13700 nM
Beside the measured number, compound 4's estimate is 3.1-fold (0.49 log units) above it; the whole stated range lies above it.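

In this assay, methoxy in place of chloro on an aromatic carbon gave a 1.6-fold lower number from compound 3 to compound 4 (0.20 log units; within the scatter), a step within the scatter. Set beside the earlier step, the change did not carry over unchanged from one core to the other: the same change on two cores in this assay, a 2.3-fold higher number (0.37 log units; beyond the scatter) from compound 1 to compound 2 and a 1.6-fold lower number (0.20 log units; within the scatter) from compound 3 to compound 4, 3.7-fold (0.57 log units) apart, beyond the scatter of two such steps

This shows that, among these compounds, the step on one core was a poor guide to the step on the other, but with only one pair on each core it gives no rule for the series and does not show why the steps differ.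

The compounds shown leave open how an amine, a carboxylic acid or a longer chain would compare with chloro and methoxy at this place. They also leave open whether the change would follow either step on a further core.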